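The compounds below may be only part of what the source reports. "The series", "measured", "known", "first", "only" and "open" are said of these compounds alone.

Measured in a functional assay on JAR cells (Homo sapiens) for inhibition, read by MTT assay, with a stated time of 72 h, tested at 10 uM; on this read-out higher numbers stand for more inhibition at the one concentration tested (going by the name of the read-out) and lower numbers for less inhibition:
- compound 1 `CCOC(=O)C1=C(Nc2ccc(Br)cc2)S/C(=C\c2ccc[nH]2)C1=O`, 41.5%
- compound 2 `CCOC(=O)C1=C(Nc2cccc(F)c2)S/C(=C\c2ccc[nH]2)C1=O`, 45.4%
- compound 3 `CCOC(=O)C1=C(Nc2ccc(C(F)(F)F)cc2)S/C(=C\c2ccc[nH]2)C1=O`, 38.5%

Compound 3 gives the lowest number of the three, but the gaps to compound 1 and compound 2 both lie within the scatter, so the three compounds cannot be separated on these numbers. The two steps recorded among them are small: a number 3.9 percentage points higher from compound 1 to compound 2 (within the scatter) and a number 3 percentage points lower from compound 1 to compound 3 (within the scatter), neither beyond the scatter.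

Compound 4 `CCOC(=O)C1=C(Nc2ccc([N+](=O)[O-])cc2)S/C(=C\c2ccc[nH]2)C1=O` is not yet measured in this assay. Its change from compound 3 is nitro in place of trifluoromethyl on an aromatic carbon. For the measured compounds named here, no measured step swaps these two groups, so none bears directly on it. The step from compound 1 to compound 3 is the closest guide, since it also exchanges the substituent on that aromatic carbon, and it stayed within the scatter; the step from compound 1 to compound 2 shows the same for a different variation of the same ring. A step of a number 2.5 percentage points higher from compound 3 to compound 4 (within the scatter) is therefore expected, that is, none beyond the scatter. Compound 4 is estimated at 41%, between 30% and 52%.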

Compound 4, a percentage reported as inhibition, at one concentration (the size of the read-out at that concentration, not a potency): 54.9%
Beside the measured number, compound 4's estimate is 13.9 percentage points below it; measured number above the stated range.
By their numbers in this assay, from the lowest: compounds 3, 1, 2 and 4 (each within the scatter of the next, the first and the last beyond it).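

For the compounds shown here, at the aromatic carbon para to a large group, the identity of the substituent now matters in this assay, which the earlier steps did not show: nitro in place of trifluoromethyl gives a modest change beyond the scatter (a number 16.4 percentage points higher from compound 3 to compound 4 (beyond the scatter)), and nitro in place of bromo gives another (a number 13.4 percentage points higher from compound 1 to compound 4 (beyond the scatter)). The separation is not complete, since 4-nitrophenyl in place of 3-fluorophenyl stays within the scatter (a number 9.5 percentage points higher from compound 2 to compound 4 (within the scatter)), so compound 2 goes against any reading of nitro as set apart from all the other substituents shown. No available evidence bears on this result.

On these data alone, whether an amine, a nitrile or a carboxylic acid on that aromatic carbon would match nitro remains open. Also open are how the step behaves with the rest of the core changed and what it means for potency, as only one concentration is shown.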